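From a hydroxyl to a fluorine on a short chain

The source may report more compounds than this note shows. Statements on the series, on what has been measured and on what is new or still open speak of the compounds shown alone.

Compound 1 `CC(=O)OCCc1c(C)[nH]c(=O)[nH]c1=O` gives > 100000 nM in a functional assay on MCF7 cells (Homo sapiens) for antiproliferative activity, read by MTT assay, with a stated time of 24 h (a higher number here means a weaker inhibitor, a lower number a stronger inhibitor), and this is a limit of the assay, not a number. Compound 2 `COc1nc(C)c(CCO)c(OC)n1` gives > 100000 nM, also a limit. Compound 3 `COc1nc(Cl)nc(C)c1CCO` gives > 100000 nM, again a limit. Because (the limit of > 100000 nM in this assay, at which 3 of the 3 values shown sit), the step that the two limits leave unreadable from compound 2 to compound 3 cannot be read. Compound 2 therefore stands only at a limit, with no number of its own. Compound 4 `COc1nc(C)c(CCF)c(OC)n1` differs from compound 2 by fluoro in place of hydroxy on a saturated chain carbon, two bonds along the chain from an aromatic carbon. For the measured compounds named here, no measured step bears on this change, so nothing beyond the scatter is expected in this assay. The step that the limit leaves unreadable from compound 2 to compound 4 is expected to be none beyond the scatter. Compound 4 is expected to give 150000 nM, between 50000 nM and 500000 nM.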

Compound 4, half-maximal inhibitory concentration: > 100000 nM
Compound 4 was reported as a limit; the forecaster's own chance of this, stated with the estimate: 85%; the middle value lies beyond the limit too.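

The step from compound 2 to compound 4 cannot be read, because both values are limits and not numbers: the limit of > 100000 nM in this assay, at which 4 of the 4 values shown sit.

Whether fluoro in place of hydroxy changes activity at all stays open, and none of the compounds shown gives a number of its own.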